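A Methyl Group Added to the Benzyl of Compound 2

The compounds below may be only part of what the source reports. "The series", "measured", "known", "first", "only" and "open" are said of these compounds alone.

Measured so far in a functional assay on NCI-H460 cells (Homo sapiens) for cytotoxicity, read by MTT assay, with a stated time of 72 h; on this read-out higher numbers stand for weaker inhibition and lower numbers for stronger inhibition
Compound 1 `Cc1ccc(Cn2cc(/C=N/NC(=O)Nc3nc4ccc(CN5CCC(C)CC5)cc4s3)c3ccccc32)cc1` gives 410 nM
Compound 2 `CN(C)Cc1ccc2nc(NC(=O)N/N=C/c3cn(Cc4ccccc4)c4ccccc34)sc2c1` gives 400 nM

Compound 2 stands level with compound 1 in this assay and the two values lie within the usual scatter of each other, so neither can be ranked ahead. Compound 3 (`Cc1ccc(Cn2cc(/C=N/NC(=O)Nc3nc4ccc(CN(C)C)cc4s3)c3ccccc32)cc1`) has not yet been measured. It departs from compound 2 in one place, with methyl in place of hydrogen on an aromatic carbon, para to a large group, so that benzyl becomes 4-methylbenzyl (methyl in place of hydrogen on an aromatic carbon). Among the compounds with values here, no pair of measured compounds isolates this change, so the data give no direct size for it. Within the data shown here, the only hint comes from compound 1, which already carries the 4-methylbenzyl and gives 410 nM in this assay while also differing from compound 3 elsewhere, which makes it a loose guide. The expected no change at the digits printed from compound 2 to compound 3 (within the scatter) stays within the scatter, with no direction favoured. Compound 3 is estimated at 400 nM (expected range 170 nM to 950 nM).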

Compound 3, half-maximal inhibitory concentration: 200 nM
For compound 3 the middle estimate is 2.0-fold (0.30 log units) above the measured one; the measured number falls inside the stated range.
By their numbers in this assay, from the lowest: compounds 3, 2 and 1 (each within the scatter of the next, the first and the last beyond it).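

In this assay, within the data shown here, compound 3 gives the first direct reading of methyl in place of hydrogen on this aromatic carbon, with a 2.0-fold lower number from compound 2 to compound 3 (0.30 log units; within the scatter), so benzyl and 4-methylbenzyl cannot be told apart here. Compound 3 also opens a second comparison in which only one place differs: with the 4-methylbenzyl held constant, dimethylamino in place of 4-methylpiperidin-1-yl on the saturated chain carbon gives a 2.1-fold lower number from compound 1 to compound 3 (0.31 log units; beyond the scatter), a modest step but the only one of the two that clears the scatter. No independent measurement bears on why either step has the size it does.

The compounds shown leave open whether a chlorine atom, a methoxy group or a trifluoromethyl group in the same place on the benzyl would read differently from methyl. They also leave open how a morpholine or a piperazine would compare with dimethylamino on the same chain carbon, and whether the amine step would keep its size with plain benzyl in place of 4-methylbenzyl.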